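This account rests on a few compounds, and the source may have more. Where it says the series, first, only, none or still open, it means among the compounds named here.

Measured in a physicochemical assay for solubility, in phosphate buffer, at pH 7.4; a lower number here means a less soluble compound, a higher number a more soluble compound:
- Compound 1 `N#Cc1c(-c2ccc(OCC3CCOC3)c(OC(F)(F)F)c2)nc(N)[nH]c1=O`: 86000 nM
- Compound 2 `Nc1nc(-c2cccc(OC(F)(F)F)c2)cc(=O)[nH]1`: 330000 nM

Compound 1 has the lower of the two numbers, and compound 2 lies above it by more than the usual scatter. Compound 3 `Nc1nc(-c2ccc(OCC3CCOC3)c(OC(F)(F)F)c2)c(Cl)c(=O)[nH]1` has chloro in place of cyano on an aromatic carbon of compound 1 (chloro in place of cyano on an aromatic carbon). For the measured compounds named here, no measured pair shows this swap, so any expectation remains loose. A modest fall in this assay is expected, only slightly beyond the scatter. The estimated change is a 2.2-fold lower number from compound 1 to compound 3 (0.33 log units; beyond the scatter). For compound 3 the expected value is 40000 nM, with an estimated range from 12000 nM to 130000 nM.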

Compound 3, solubility: 45000 nM
Beside the measured number, compound 3's estimate is 1.1-fold (0.05 log units) below it, and the stated range covers the measured number.
By their numbers in this assay, from the lowest: compounds 3 and 1 (each within the scatter of the next); then compound 2.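

In this assay, for the compounds shown here, chloro in place of cyano on the aromatic carbon para to an amino group gives a 1.9-fold lower number from compound 1 to compound 3 (0.28 log units; within the scatter) as the first direct reading at this position. At this position, then, the two groups cannot be told apart in this measurement, even though cyano has a triple bond and an extra heavy atom. No supporting measurement bears on why the two compounds read alike. As far as these compounds go, whether a methyl, a methoxy or an amine on the same carbon would also read alike remains open. A single swap on one core also cannot show whether the same holds on other cores.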